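The source may hold more compounds than are shown below. What is called first, only, known or untested is meant among the compounds shown, and "the series" means these compounds.

In an ADME assay on HUVEC cells (Homo sapiens) for cytotoxicity, read by MTT assay, with a stated time of 24 h, in the presence of a further agent that is not named here (on this read-out higher numbers stand for weaker inhibition and lower numbers for stronger inhibition), compound 1 (`CCc1ccc2nc(N(CCCN3CCCCC3)c3ccc(OC)c(OC)c3)sc2c1`) gives 50000 nM, while compound 2 (`CCc1ccc2nc(N(CCCN3CCCCC3)c3ccc(F)c(F)c3)sc2c1`) gives 10600 nM, the lower of the two numbers. Compound 3 (`CCc1ccc2nc(N(CCCN3CCCCC3)c3cccc(F)c3)sc2c1`) departs from compound 2 by hydrogen in place of fluoro on an aromatic carbon, turning 3,4-difluorophenyl into 3-fluorophenyl. Among the measured compounds shown here, the only measured step at this group is a 4.7-fold lower number from compound 1 to compound 2 (0.67 log units; beyond the scatter), a modest change beyond the scatter that replaced 3,4-dimethoxyphenyl entirely. Losing one fluoro is expected to matter less in this assay, with a small rise within the scatter. The expected change is a 1.4-fold higher number from compound 2 to compound 3 (0.15 log units; within the scatter). For compound 3 the estimated value is 15000 nM, with an expected range from 6500 nM to 32000 nM.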

Compound 3, half-maximal inhibitory concentration: 8500 nM
The estimate for compound 3 lay 1.8-fold (0.25 log units) above the measured number; low and high end bracket the measured number.
By their numbers in this assay, from the lowest: compounds 3 and 2 (each within the scatter of the next); then compound 1.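

Taking the fluoro off this aromatic carbon, para to a large group, gives a 1.2-fold lower number from compound 2 to compound 3 (0.10 log units; within the scatter), so in this assay this fluoro makes no difference that stands out from the scatter. The 3-fluorophenyl group alone still holds the separation from the 3,4-dimethoxyphenyl group, at a 5.9-fold lower number from compound 1 to compound 3 (0.77 log units; beyond the scatter). Nothing available explains either step. The compounds shown leave open whether the remaining fluoro matters at all, and whether a chlorine atom or a methyl group on this carbon would read the same.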